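A few compounds are considered here, and "the series" means these few. Any claim that something is new, unique, unknown or untested is made for them only; others in the source may bear on it.

For the measured compounds named here, compound 1 `O=C(N/N=C/c1ccc(F)cc1F)c1cc(-c2ccc(Cl)cc2)nn1Cc1ccc(Cl)nc1` is the only compound of the series with a measured number: in a functional assay on A549 cells (Homo sapiens) for antiproliferative activity, read by BrdU incorporation, with a stated time of 48 h (a higher number here means a weaker inhibitor, a lower number a stronger inhibitor), compound 1 gives 9050 nM. Compound 2 `CC(C)(C)c1ccc(Cn2nc(-c3ccc(Cl)cc3)cc2C(=O)N/N=C/c2ccc(F)cc2F)cc1` gives only a limit in this assay, > 100000 nM. Going by the values given here, the single measured step, an at least 11-fold higher number from compound 1 to compound 2 (1.04 log units; beyond the scatter), ends at the limit of > 100000 nM in this assay, at which 1 of the 2 values shown sits. Compound 3 `N#Cc1ccc(/C=N/NC(=O)c2cc(-c3ccc(Cl)cc3)nn2Cc2ccc(Cl)nc2)cc1` alters a different place: 4-cyanophenyl in place of 2,4-difluorophenyl on a carbon with a double bond to nitrogen. Among the compounds with values here, no measured step touches that carbon, so the measured step offers no direct guide. Compound 3 is therefore expected to change little, with a step of a 1.0-fold lower number from compound 1 to compound 3 (0.00 log units; within the scatter) and an estimate of 9000 nM (3000 nM to 30000 nM).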

Compound 3, half-maximal inhibitory concentration: > 100000 nM
Compound 3: only a limit was reported; the forecaster's own chance of this, stated with the estimate: 15%; middle value at least 11-fold (1.04 log units) away from the limit.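

In this assay, the group on the carbon with a double bond to nitrogen proves as sensitive as the group changed in compound 2: 4-cyanophenyl in place of 2,4-difluorophenyl gives an at least 11-fold higher number from compound 1 to compound 3 (1.04 log units; beyond the scatter). The value of compound 3 is a limit, so the full size of this step cannot be read. Compound 1 is now the only compound with a number: the limit of > 100000 nM in this assay, at which 2 of the 3 values shown sit.

Still open, as far as these compounds go, is whether the loss follows from the departure of the two fluorines or the arrival of the nitrile. A plain phenyl or a 4-fluorophenyl at this carbon would separate the two.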